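Benzofuranyl for phenyl on the shared core

The source may report more compounds than this note shows. Statements on the series, on what has been measured and on what is new or still open speak of the compounds shown alone.

Compound 1 `Nc1nc2c(c(-c3ccccc3)cn2[C@@H]2O[C@H](CO)[C@@H](O)[C@H]2O)c(=O)[nH]1` gives only a limit in a functional assay on HeLa S3 cells (Homo sapiens) for antiproliferative activity, read by XTT assay, with a stated time of 72 h (a lower number here means a stronger inhibitor, a higher number a weaker inhibitor), > 20000 nM. Compound 2 `C#Cc1cn([C@@H]2O[C@H](CO)[C@@H](O)[C@H]2O)c2ncnc(C)c12` gives a number in this assay, 14700 nM. Compound 3 `C#Cc1cn([C@@H]2O[C@H](CO)[C@@H](O)[C@H]2O)c2ncnc(NC)c12` again returns a limit in this assay, > 20000 nM. Within the data shown here, the one measured step, an at least 1.3-fold higher number from compound 2 to compound 3 (0.13 log units; that floor lies within the scatter), concerns methylamino in place of methyl on an aromatic carbon and stays within the scatter. Compound 1 thus stands at the limit of > 20000 nM in this assay, at which 2 of the 3 values shown sit, so only a floor is known for it, and only compound 2 supplies an actual number in the series.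

Compound 4 `Nc1nc2c(c(-c3cc4ccccc4o3)cn2[C@@H]2O[C@H](CO)[C@@H](O)[C@H]2O)c(=O)[nH]1` differs from compound 1 by 1-benzofuran-2-yl in place of phenyl on an aromatic carbon. Among the measured compounds shown here, no measured step touches an aryl group at this place; the one step known speaks to a different part of the core and was within the scatter, so it gives no direction for this change. With compound 1 at a limit, the expectation for compound 4 is that it stays near that limit in this assay. The expected step is an at least 1.1-fold lower number from compound 1 to compound 4 (0.04 log units; that floor lies within the scatter). Compound 4 is therefore estimated at 18000 nM, with a range from 6000 nM to 40000 nM.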

Compound 4, half-maximal inhibitory concentration: > 20000 nM
Compound 4 ended at the assay's limit; the forecaster's own chance of this, stated with the estimate: 60%; at least 1.1-fold (0.04 log units) between middle value and limit.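

Compound 1 and compound 4 both give a limit rather than a number in this assay, so no step can be read for 1-benzofuran-2-yl in place of phenyl: the limit of > 20000 nM in this assay, at which 3 of the 4 values shown sit.

The compounds shown leave open how these two groups compare on the shared core.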